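From 2-chlorophenyl to 3-cyanophenyl on the shared core

The source may hold more compounds than are shown below. What is called first, only, known or untested is meant among the compounds shown, and "the series" means these compounds.

In an ADME assay on HUVEC cells (Homo sapiens) for inhibition, read by CCK-8 assay, with a stated time of 24 h, in the presence of a further agent that is not named here (on this read-out lower numbers stand for stronger inhibition and higher numbers for weaker inhibition), compound 3 `O=C1Nc2ccccc2/C1=C/c1ccc(-c2cn(-c3ccccc3Cl)nn2)cc1` stands at > 20000 nM, which is a limit of the assay and not a number. It is the only such case among the measured compounds: the limit of > 20000 nM in this assay, at which 1 of the 3 values shown sits.

The other two compounds give numbers: compound 1 `Cc1cccc(-n2cc(-c3ccc(/C=C4\C(=O)Nc5ccccc54)cc3)nn2)c1` gives 13700 nM and compound 2 `O=C1Nc2ccccc2/C1=C/c1ccc(-c2cn(-c3ccccc3F)nn2)cc1` gives 19300 nM.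

The next change leads to compound 4 `N#Cc1cccc(-n2cc(-c3ccc(/C=C4\C(=O)Nc5ccccc54)cc3)nn2)c1`, with 3-cyanophenyl in place of 2-chlorophenyl on an aromatic nitrogen.

Within the data shown here, three measured steps bear on it, all changes of the same group or its substituent: a 1.4-fold higher number from compound 1 to compound 2 (0.15 log units; within the scatter), an at least 1.4-fold higher number from compound 1 to compound 3 (0.16 log units; that floor lies within the scatter) and an at least 1.0-fold higher number from compound 2 to compound 3 (0.01 log units; that floor lies within the scatter). Among the measured compounds shown here, none of them shows a change beyond the scatter, and no compound with a nitrile has been measured yet.

A step beyond the scatter is therefore not expected in this assay, in either direction. The estimated step is an at least 1.3-fold lower number from compound 3 to compound 4 (0.12 log units; that floor lies within the scatter).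

The expected value for compound 4 is 15000 nM, with an estimated range from 7000 nM to 30000 nM.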

Compound 4, half-maximal inhibitory concentration: > 20000 nM
Compound 4: a limit, no number (the forecaster's own chance of this, stated with the estimate: 30%); middle value at least 1.3-fold (0.12 log units) from the limit.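

In this assay compound 4 gives > 20000 nM, a limit of the assay and not a number. With a nitrile on the aryl group at this aromatic nitrogen, cyano in place of methyl gives an at least 1.4-fold higher number from compound 1 to compound 4 (0.16 log units; that floor lies within the scatter), and 3-cyanophenyl in place of 2-fluorophenyl gives an at least 1.0-fold higher number from compound 2 to compound 4 (0.01 log units; that floor lies within the scatter), so the one hydrogen-bond acceptor on this group comes with no change beyond the scatter. The step between compound 3 and compound 4 cannot be read, and the limit now takes in both a chlorine-bearing and a nitrile-bearing aryl group: the limit of > 20000 nM in this assay, at which 2 of the 4 values shown sit.

No step shown lies beyond the scatter, so it stays open whether any change at this position can give a clearly lower number. An amine or a carboxylic acid on the phenyl ring, or a longer chain in place of the ring, would test this.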